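The source may hold more compounds than are shown below. What is called first, only, known or untested is meant among the compounds shown, and "the series" means these compounds.

Measured so far in a functional assay on cells (Cancer cell lines, Homo sapiens) for inhibition; a lower number here means a stronger inhibitor of growth, a higher number a weaker inhibitor of growth:
- compound 1 `Cc1cn2c(/C=N/NC(=N)N)c(-c3ccsc3)nc2s1`: 7590 nM
- compound 2 `N=C(N)N/N=C/c1c(-c2cc(Cl)sc2Cl)nc2n1CCS2`: 8130 nM
- compound 3 `N=C(N)N/N=C/c1c(-c2ccsc2)nc2sccn12`: 14800 nM

Compound 3, at 14800 nM, lies within the usual scatter of both compound 1 and compound 2, so these three numbers cannot be ranked against one another.

Compound 4 `N=C(N)N/N=C/c1c(-c2cccs2)nc2sccn12` has not yet been measured. It contains the same atoms as compound 3, joined differently: thiophen-2-yl stands in place of thiophen-3-yl on an aromatic carbon (thiophen-2-yl in place of thiophen-3-yl on an aromatic carbon).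

For the measured compounds named here, no measured step tests this swap directly. Going by the values given here, the only step available, a 1.9-fold higher number from compound 1 to compound 3 (0.29 log units; within the scatter), is a different change, hydrogen in place of methyl on an aromatic carbon, and it stays within the scatter. Among the compounds with values here, compound 2 differs from compound 3 in more than one place, so it offers no clean single step. The three values still show that these structural differences have so far left the numbers within a narrow band.

With so little evidence, no shift beyond the scatter is expected, in either direction. The expected step is a 1.1-fold lower number from compound 3 to compound 4 (0.06 log units; within the scatter). The estimate for compound 4 is 13000 nM, with an expected range of 6000 nM to 28000 nM.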

Compound 4, concentration for 50% growth inhibition: 12300 nM
Beside the measured number, compound 4's estimate is 1.1-fold (0.02 log units) above it; the measured number falls inside the stated range.
By their numbers in this assay, from the lowest: compounds 1, 2, 4 and 3 (each within the scatter of the next).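

Among the compounds shown, this pair alone tests how the thiophene ring is joined to the shared core, on an aromatic carbon of the five-membered aromatic ring with 2 nitrogen. In this assay, thiophen-2-yl in place of thiophen-3-yl gives a 1.2-fold lower number from compound 3 to compound 4 (0.08 log units; within the scatter), so the two compounds cannot be told apart, and at this position this rearrangement of the same atoms has no effect that the assay can resolve. No other measurement here bears on this result, so the growth numbers alone describe it.

On these data alone, it remains open whether a different group at this position, such as a phenyl ring, a pyridine ring or an amine, would shift the number beyond the scatter, as neither thiophene tells how much this position can matter in this assay. As far as these compounds go, it is also open whether the same thiophene swap would give a similarly small step on the core of compound 1, which carries a methyl group that compound 3 and compound 4 lack.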